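A few compounds are considered here, and "the series" means these few. Any claim that something is new, unique, unknown or untested is made for them only; others in the source may bear on it.

Compound 1 `Cc1nc(C(=O)Nc2ccc(Cl)c(-c3nnc4c(Cl)cccn34)c2)cs1` in a functional assay on U-251 cells (Homo sapiens) for antiproliferative activity, read by MTT assay, with a stated time of 72 h (a lower number here means a stronger inhibitor, a higher number a weaker inhibitor), gives 74300 nM. Compound 2 `O=C(Nc1ccc(Cl)c(-c2nnc3c(Cl)cccn23)c1)c1cccnc1` in this assay gives > 100000 nM, which is a limit of the assay and not a number. Compound 3 `O=C(Nc1ccc(Cl)c(-c2nnc3c(Cl)cccn23)c1)c1ccc(Cl)cc1` in this assay gives > 100000 nM, also a limit of the assay. Compound 3 therefore stands at the ceiling of the series, where (the limit of > 100000 nM in this assay, at which 2 of the 3 values shown sit). The step of an at least 1.3-fold higher number from compound 1 to compound 2 (0.12 log units; that floor lies within the scatter) and the step of an at least 1.3-fold higher number from compound 1 to compound 3 (0.12 log units; that floor lies within the scatter) are both read against that limit, and the step that the two limits leave unreadable from compound 2 to compound 3 cannot be sized from two limits. Compound 4 `O=C(Nc1ccc(Cl)c(-c2nnc3c(Cl)cccn23)c1)c1ccccc1` differs from compound 3 by hydrogen in place of chloro on an aromatic carbon. Among the compounds with values here, no measured step changes the ring on the carbonyl carbon in this way; the two steps that swap that ring only move between a weak number and a limit. Compound 4 is accordingly expected to stay weak in this assay, with an estimated step that the limit leaves unreadable from compound 3 to compound 4 that does not stand beyond the scatter. Compound 4 is estimated at 130000 nM in this assay. For compound 4 the expected range runs from 40000 nM to 400000 nM.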

Compound 4, half-maximal inhibitory concentration: 73500 nM
Compound 4: the middle estimate sits 1.8-fold (0.25 log units) above what was measured, and the stated range covers the measured number.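

In this assay, hydrogen in place of chloro gives an at least 1.3-fold lower number from compound 3 to compound 4 (0.13 log units; that floor lies within the scatter), and phenyl in place of pyridin-3-yl gives an at least 1.3-fold lower number from compound 2 to compound 4 (0.13 log units; that floor lies within the scatter); both are floors set by a limit and stay within the scatter, so neither shows a real gain. Phenyl in place of 2-methyl-1,3-thiazol-4-yl gives a 1.0-fold lower number from compound 1 to compound 4 (0.00 log units; within the scatter), so the unsubstituted phenyl and the thiazole cannot be told apart on the carbonyl carbon. Compound 2 and compound 3 remain at a limit of the assay, not at a number: the limit of > 100000 nM in this assay, at which 2 of the 4 values shown sit.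

The step between compound 2 and compound 3 still cannot be read. As far as these compounds go, how an amine, a carboxylic acid or a methoxy group at the place of the chloro would read in this assay stays open, as does any change to the shared core.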